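The source may report more compounds than this note shows. Statements on the series, on what has been measured and on what is new or still open speak of the compounds shown alone.

The series shares one core, seen in compound 1 `CC1=C(/C=C/C(=O)/C=C/c2ccccc2Cl)C(C)(C)CCC1`, which in a functional assay on Hep cells (Homo sapiens) for cytotoxicity, read by sulforhodamine B assay, with a stated time of 48 h (a higher number here means a weaker inhibitor, a lower number a stronger inhibitor), gives 54200 nM. Compound 2 `COc1ccccc1/C=C/C(=O)/C=C/C1=C(C)CCCC1(C)C` carries a methoxy group on the aromatic carbon where compound 1 carries a chloro group, and in this assay compound 2 gives 38900 nM. Compound 3 `CC1=C(/C=C/C(=O)/C=C/c2ccccc2[N+](=O)[O-])C(C)(C)CCC1` carries a nitro group on that aromatic carbon, and in this assay compound 3 gives 44900 nM. Among these three numbers compound 3 stands second highest; its nearest neighbour is compound 2 and its furthest compound 1, and every pair lies within the scatter: a 1.4-fold lower number from compound 1 to compound 2 (0.14 log units; within the scatter), a 1.2-fold lower number from compound 1 to compound 3 (0.08 log units; within the scatter), a 1.2-fold higher number from compound 2 to compound 3 (0.06 log units; within the scatter). Compound 4 `CC1=C(/C=C/C(=O)/C=C/c2ccccc2F)C(C)(C)CCC1` differs from compound 3 in one place: fluoro in place of nitro on an aromatic carbon. All three measured steps exchange one substituent on this same aromatic carbon, and none of them moved the number beyond the scatter, so the step of a 1.0-fold higher number from compound 3 to compound 4 (0.00 log units; within the scatter) is expected to be of that same small size, with no direction that can be read from these data. Compound 4 is therefore estimated to give 45000 nM in this assay, with a range from 22000 nM to 90000 nM.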

Compound 4, half-maximal inhibitory concentration: 23600 nM
For compound 4 the middle estimate is 1.9-fold (0.28 log units) above the measured one, within the range that was stated.
By their numbers in this assay, from the lowest: compounds 4, 2, 3 and 1 (each within the scatter of the next, the first and the last beyond it).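

Fluoro gives the only step at this aromatic carbon that passes the scatter, a modest one in this assay (a 2.3-fold lower number from compound 1 to compound 4 (0.36 log units; beyond the scatter)) for fluoro in place of chloro. Against the other two groups it stays within the scatter, both for nitro (a 1.9-fold lower number from compound 3 to compound 4 (0.28 log units; within the scatter)) and for methoxy (a 1.6-fold lower number from compound 2 to compound 4 (0.22 log units; within the scatter)). The position therefore responds to the exchange of one substituent for another, but only slightly, and only between fluoro and chloro among these four compounds. Nothing available explains this step.

On these data alone, whether an amine, a carboxylic acid or a hydroxyl group on this aromatic carbon would carry the number further from these values remains open. So does whether fluoro in place of chloro would give a step of this size on another carbon of the same ring.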